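The source may report more compounds than this note shows. Statements on the series, on what has been measured and on what is new or still open speak of the compounds shown alone.

Measured compounds, largest response reached in a functional assay on U2OS cells with metabotropic glutamate receptor 5 (Homo sapiens) as the target, read by calcium flux; a lower number here means a smaller maximal response, a higher number a larger maximal response:
- compound 3, `Cc1ccc(-c2noc(C3CCc4c(nnn4C(C)(C)C)C3)n2)cn1`, gives 67%
- compound 1, `CN1CCC(n2nnc3c2CCC(c2nc(-c4ccc(F)cc4)no2)C3)CC1`, gives 91%
- compound 2, `CC(C)n1nnc2c1CCC(c1nc(-c3ccc(F)cc3)no1)C2`, gives 98%

Compound 3 has the lowest of the three numbers in this assay. Its nearest neighbour is compound 1, whose number is higher by an amount beyond the scatter; the furthest is compound 2, higher again and also beyond the scatter. Within the data shown here, no step has been computed for either of these pairs, so only the two values speak.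

Among the measured compounds shown here, the one measured step within the set, a number 7 percentage points higher from compound 1 to compound 2 (within the scatter), concerns the substituent on the aromatic nitrogen of the shared core and leaves the oxadiazole end untouched.

Compound 4, `CC(C)Cc1noc(C2CCc3c(nnn3C(C)(C)C)C2)n1`, has not been measured in this assay. It differs from compound 3 by isobutyl in place of 6-methylpyridin-3-yl on an aromatic carbon. For the measured compounds named here, no measured step bears on a change at this aromatic carbon: the only measured step sits at a different place and stayed within the scatter. The expectation therefore rests on the bare observation that every measured compound carries an aromatic ring at this carbon, and compound 4 does not.

For compound 4 the expected value in this assay is 50%, within a range of 15% to 90%, that is an estimated step of a number 17 percentage points lower from compound 3 to compound 4 (beyond the scatter).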

Compound 4, largest response reached (reported as percent of maximum), in percent of the reference or control that the assay uses: 66%
Estimate against measurement, compound 4: 16 percentage points below; the range from low to high includes it.
By their numbers in this assay, from the lowest: compounds 4 and 3 (each within the scatter of the next); then compounds 1 and 2 (each within the scatter of the next).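

In this assay isobutyl in place of 6-methylpyridin-3-yl, on the aromatic carbon between two ring nitrogen atoms, gives a number 1 percentage points lower from compound 3 to compound 4 (within the scatter) and so leaves the maximal response unchanged within the scatter. Among these compounds, this is the first step read at this position, and it shows that, with the group carried by compound 3 and compound 4 on the aromatic nitrogen, the six-membered aromatic ring, its ring nitrogen and its hydrogen-bond acceptor can all leave without a measurable change in this read-out. No supporting data are available to explain why the response holds across this change.

Still open, on these data alone, is whether the position tolerates substituents of other kinds, such as an amine, a carboxylic acid, a longer chain or a saturated ring, since a single non-aromatic group defines the present result. Also unresolved is whether the same swap would leave the response unchanged with isopropyl or 1-methylpiperidin-4-yl on the aromatic nitrogen, where only the fluorinated aryl end has been paired with those groups.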